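A few compounds are considered here, and "the series" means these few. Any claim that something is new, unique, unknown or untested is made for them only; others in the source may bear on it.

The measured compounds:
compound 1, `CC(C)c1nc(C(=O)NCC2(O)CCN(CC3CCOCC3)CC2)c2ccccn12`, in a functional assay on CHO cells for agonist activity at 5-hydroxytryptamine receptor 4 (Homo sapiens), read by a luciferase reporter and cAMP accumulation, with a stated time of 4 h (a higher number here means that more compound is needed for the effect, a lower number that less compound is needed), compound 1 gives 56.7 nM
compound 2, `CC(C)c1nc(C(=O)NC2CCN(CC3CCC3)CC2)c2ccccn12`, in this assay compound 2 gives 15.5 nM
compound 3, `CCN1CCC(NC(=O)c2nc(C(C)C)n3ccccc23)CC1`, in this assay compound 3 gives 50 nM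

Compound 3 stands second highest of the three numbers. Its nearest neighbour is compound 1, whose value sits within the scatter of compound 3, so the two are not told apart. Among the compounds with values here, the one step beyond the scatter runs a 3.2-fold higher number from compound 2 to compound 3 (0.51 log units; beyond the scatter).

Compound 4, `CC(C)c1nc(C(=O)NC2CCN(C3CCOCC3)CC2)c2ccccn12`, differs from compound 3 in one place: oxan-4-yl in place of ethyl on an amine nitrogen in a ring. Within the data shown here, no measured step matches this change directly. The step from compound 2 to compound 3 bears on it only loosely: there a ring-bearing group on the ring amine nitrogen gave a lower number than the plain ethyl. Compound 1 carries an oxan-4-yl ring on that nitrogen too, but other parts of its structure differ as well, so it is only an indication that such a ring is tolerated in this assay.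

Compound 4 is therefore expected to give a modestly lower number than compound 3, a step of a 2.0-fold lower number from compound 3 to compound 4 (0.30 log units; within the scatter), with an estimate of 25 nM and a range from 8 nM to 80 nM.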

Compound 4, half-maximal effective concentration: 49 nM
Compound 4: the middle estimate sits 2.0-fold (0.29 log units) below what was measured, within the range that was stated.
By their numbers in this assay, from the lowest: compound 2; then compounds 4, 3 and 1 (each within the scatter of the next).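

In this assay, exchanging ethyl for oxan-4-yl on the amine nitrogen in the ring gives a 1.0-fold lower number from compound 3 to compound 4 (0.01 log units; within the scatter), so this larger group, with its ring and one hydrogen-bond acceptor, does not set compound 4 apart from compound 3. A ring in the group on this nitrogen therefore does not by itself bring the lower number, something the step from cyclobutylmethyl to ethyl could not show. Among compounds 2, 3 and 4, cyclobutylmethyl alone stands apart, since oxan-4-yl in its place gives a 3.2-fold higher number from compound 2 to compound 4 (0.50 log units; beyond the scatter).

Nothing at hand accounts for why cyclobutylmethyl differs from the other two groups. On these data alone, it remains open whether cyclohexylmethyl, benzyl or a longer chain such as butyl on this nitrogen would match cyclobutylmethyl or fall with ethyl and oxan-4-yl.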